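The source may report more compounds than this note shows. Statements on the series, on what has been measured and on what is new or still open speak of the compounds shown alone.

In a functional assay on A-431 cells (Homo sapiens), read by propidium iodide staining, with a stated time of 24 h (on this read-out higher numbers stand for an effect only at larger amounts of compound and lower numbers for an effect already at smaller amounts), compound 1 `FC(F)(F)c1cccc(-c2nnc(-c3cccnc3NCc3cn[nH]c3)[nH]2)c1` is recorded only as a limit, > 10000 nM. Compound 2 `CS(=O)(=O)c1ccc(-c2nnc(-c3cccnc3NCC3COCCO3)[nH]2)cc1` is likewise recorded only as a limit, > 10000 nM. Going by the values given here, compound 3 `c1cnc(NCc2ccncc2)c(-c2nnc(Nc3ccc4c(c3)OCCO4)o2)c1` gives 18 nM, the only true number in the set. Compound 1 and compound 2 share one reading: the limit of > 10000 nM in this assay, at which 2 of the 3 values shown sit.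

Compound 4 `c1cnc(NCc2ccc3ncccc3c2)c(-c2nnc(Nc3ccc4c(c3)OCCO4)o2)c1` keeps the rest of compound 3 and carries quinolin-6-yl in place of pyridin-4-yl on a saturated chain carbon bound to a nitrogen on an aromatic ring. Among the compounds with values here, no measured pair in the set differs at this place alone, so the expectation rests on compound 3 at 18 nM and on the structural change. A modest rise in the number is expected rather than a fall to the limit, with the estimated size a 2.5-fold higher number from compound 3 to compound 4 (0.40 log units; beyond the scatter). For compound 4, the estimated value in this assay is 45 nM, with an expected range of 10 nM to 300 nM.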

Compound 4, half-maximal effective concentration: 18 nM
Beside the measured number, compound 4's estimate is 2.5-fold (0.40 log units) above it; the measured number falls inside the stated range.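

In this assay, quinolin-6-yl in place of pyridin-4-yl on a saturated chain carbon bound to a nitrogen on an aromatic ring gives no change at the digits printed from compound 3 to compound 4 (within the scatter), the first step read at this place. The entering group has 10 heavy atoms against 6 and adds a six-membered aromatic ring of carbon only, with hydrogen-bond donors and acceptors counted the same, so this place takes the added ring without a change beyond the scatter. The data shown give no cause for this outcome.

Open, from the compounds shown here alone, is whether a carboxylic acid or an amine on the ring at this place, or a longer chain in place of the methyl link, would keep the reading. Compound 3 and compound 4 also share the rest of the structure, so this step says nothing about changes elsewhere on the core.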